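Swapping the Aryl Arm for a Cyclic Amide

The source may hold more compounds than are shown below. What is called first, only, known or untested is meant among the compounds shown, and "the series" means these compounds.

Of the compounds shown here, three sharing one core have been measured. Compound 1 `N#Cc1cccc(-c2cnc(C(=O)CCCCCCc3ccccc3)o2)c1` gives 15 nM in an assay (Rattus norvegicus) for inhibition of Fatty-acid amide hydrolase 1 (Homo sapiens); a higher number here means a weaker inhibitor, a lower number a stronger inhibitor. Compound 2 `COC(=O)c1ccc(-c2cnc(C(=O)CCCCCCc3ccccc3)o2)cc1` gives 40 nM in this assay. Compound 3 `Cc1cccnc1-c1cnc(C(=O)CCCCCCc2ccccc2)o1` gives 15 nM in this assay. Among the measured compounds shown here, the single one-place step among them, no change at the digits printed from compound 1 to compound 3 (within the scatter), stays within the scatter. Compound 3 therefore stands level with compound 1, the pair holding the lowest numbers of the three, while compound 2 shows a higher number than either.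

Compound 4 `O=C(CCCCCCc1ccccc1)c1ncc(C(=O)N2CCSCC2)o1` has not yet been measured. It differs from compound 3 in one place: (thiomorpholin-4-yl)carbonyl in place of 3-methylpyridin-2-yl on an aromatic carbon. For the measured compounds named here, no measured step covers a change of this kind. Going by the values given here, the one step available, no change at the digits printed from compound 1 to compound 3 (within the scatter), exchanges one six-membered aromatic ring for another at the same site and leaves the number unchanged, and compound 2, which also varies only at this site, gives a higher number. Since the incoming group is a non-aromatic amide rather than an aromatic ring, the expectation rests on little. The step from compound 3 to compound 4 is expected to be a 3.3-fold higher number from compound 3 to compound 4 (0.52 log units; beyond the scatter), towards a higher number. Compound 4 is expected to give 50 nM in this assay, within a range of 10 nM to 300 nM.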

Compound 4, inhibition constant: 10 nM
The estimate for compound 4 lay 5.0-fold (0.70 log units) above the measured number; measured number inside the range.
By their numbers in this assay, from the lowest: compounds 4, 1 and 3 (each within the scatter of the next); then compound 2.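

Until now this position, on an aromatic carbon next to the ring oxygen, had carried only six-membered aromatic rings, and compound 4 shows that it also tolerates a (thiomorpholin-4-yl)carbonyl, with a non-aromatic ring joined through a carbonyl. In this assay the exchange gives a 1.5-fold lower number from compound 3 to compound 4 (0.18 log units; within the scatter) and, against the nitrile-bearing ring, a 1.5-fold lower number from compound 1 to compound 4 (0.18 log units; within the scatter), so compound 4 stands level with both. Among these compounds, then, an aromatic ring directly on this carbon is not needed for a number in this range, and a group as different as this amide leaves the reading where the two aromatic rings put it; nothing available explains why the two kinds of group read alike.

What the compounds shown leave open is whether the sulfur of the thiomorpholine ring matters, which a morpholine amide with oxygen in its place or a piperidine amide with a plain carbon there would test. They also do not tell whether the ring itself is needed, as a simple dimethylamide, a secondary amide carrying an amide hydrogen or a free carboxylic acid at this position could show.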